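The source may report more compounds than this note shows. Statements on the series, on what has been measured and on what is new or still open speak of the compounds shown alone.

Measured compounds:
compound 1 `CC1(C)CC(=O)N(c2ccccc2C(=O)OCC2CCCN(CCCc3ccccc3)C2)C1=O` — 5010 nM
compound 2 `O=C(OCC1CCCN(CCCc2ccccc2)C1)c1ccccc1-n1cc(-c2ccccc2)nn1` — 4270 nM
compound 3 `O=C(OCC1CCCN(CCCc2ccccc2)C1)c1ccccc1-c1cccc2ccccc12` — 63100 nM

In an in vitro functional assay on HEK ts201 cells for antagonist activity at Neuronal acetylcholine receptor; alpha3/beta4 (Homo sapiens), read by fluorescence and calcium flux (on this read-out higher numbers stand for weaker inhibition and lower numbers for stronger inhibition), compound 3 gives the highest of the three numbers. The step of a 13-fold higher number from compound 1 to compound 3 (1.10 log units; beyond the scatter) and the step of a 15-fold higher number from compound 2 to compound 3 (1.17 log units; beyond the scatter) both lie beyond the scatter, whereas a 1.2-fold lower number from compound 1 to compound 2 (0.07 log units; within the scatter) does not; so the two ring-nitrogen-linked groups of compound 1 and compound 2 give similar numbers and the naphthalen-1-yl stands apart.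

Compound 4 `O=C(OCC1CCCN(CCCc2ccccc2)C1)c1ccccc1N1C(=O)c2ccccc2C1=O` differs from compound 3 in one place: a group of 11 heavy atoms (8 carbon, 1 nitrogen, 2 oxygen; one five-membered non-aromatic ring with 1 hetero atom, one six-membered aromatic ring of carbon only) in place of a group of 10 heavy atoms (10 carbon; 2 six-membered aromatic rings of carbon only), on an aromatic carbon. The entering group, like the 3,3-dimethyl-2,5-dioxopyrrolidin-1-yl of compound 1, is attached through nitrogen and carries a five-membered non-aromatic ring with 1 hetero atom and 2 hydrogen-bond acceptors. The step from compound 1 to compound 3 is the closest comparison, and it is large. Its reverse is therefore the expectation for compound 4: a large fall in this assay, roughly back to where compound 1 stands, estimated as a 13-fold lower number from compound 3 to compound 4 (1.10 log units; beyond the scatter). Compound 4 is expected to give about 5000 nM, within 2000 nM to 15000 nM.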

Compound 4, half-maximal inhibitory concentration: 5890 nM
Compound 4: middle estimate off by 1.2-fold (0.07 log units), on the low side; the measured number falls inside the stated range.
By their numbers in this assay, from the lowest: compounds 2, 1 and 4 (each within the scatter of the next); then compound 3.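

Notes on the group on this aromatic carbon, in this assay: the step of an 11-fold lower number from compound 3 to compound 4 (1.03 log units; beyond the scatter) shows that a six-membered aromatic ring of carbon only in the entering group does not by itself go with the high number of compound 3, since the group in compound 4 also carries such a ring. The steps of a 1.2-fold higher number from compound 1 to compound 4 (0.07 log units; within the scatter) and a 1.4-fold higher number from compound 2 to compound 4 (0.14 log units; within the scatter) both lie within the scatter, so three nitrogen-attached groups of differing ring make-up now cannot be told apart, and the naphthalen-1-yl remains the only one that stands apart. Nothing available explains this separation.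

With a single carbon-attached group in the set, the nitrogen attachment and the hydrogen-bond acceptors of the entering group cannot be separated as links to the lower numbers. Going by these compounds, whether a simple phenyl, a primary amine or a carboxylic acid on this aromatic carbon would sit with compound 3 or with compound 4 stays open.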